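The compounds below may be only part of what the source reports. "The series", "measured", "known", "first", "only" and "open" are said of these compounds alone.

Notes on the series. Compound 1, `CNC(=O)c1cc(C(=O)NC2CC2)cn(Cc2cccc3[nH]c(C)nc23)c1=O`, and compound 2, `CNC(=O)c1cc(C(=O)NC2CC2)cn(Cc2ccc(OC)cc2)c1=O`, share a common core and differ in the group on the saturated chain carbon bound to the aromatic nitrogen. Both were run in a physicochemical assay for solubility; a higher number here means a more soluble compound, a lower number a less soluble compound. Compound 1 gives >= 198 ug/mL, which is a limit of the assay and not a number. Compound 2 gives >= 143 ug/mL, likewise a limit of the assay rather than a number. On the numbers shown, compound 2 therefore stands at a limit (the limit of >= 143 ug/mL in this assay, at which 1 of the 2 values shown sits), and the other value shown also sits at a limit (the limit of >= 198 ug/mL in this assay, at which 1 of the 2 values shown sits), so no measured step between the two can be stated.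

Compound 3, `CNC(=O)c1cc(C(=O)NC2CC2)cn(Cc2cccc(C)c2)c1=O`, is not yet measured. It differs from compound 2 by 3-methylphenyl in place of 4-methoxyphenyl on a saturated chain carbon bound to an aromatic nitrogen. Going by the values given here, no measured step anchors the size of this change; the step from compound 2 to compound 3 in this assay is expected to be an at least 1.4-fold lower number from compound 2 to compound 3 (0.15 log units; that floor lies within the scatter), a modest drop that the scatter may well cover. Compound 3 is expected to give 100 ug/mL, with a range from 35 ug/mL to 200 ug/mL.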

Compound 3, solubility: >= 205 ug/mL
Compound 3: a limit, no number (the forecaster's own chance of this, stated with the estimate: 35%); middle value at least 2.0-fold (0.31 log units) from the limit.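

In this assay compound 3 gives >= 205 ug/mL, a limit of the assay and not a number. Going by these compounds alone, compound 2 gives >= 143 ug/mL, also a limit, so no step from compound 2 to compound 3 can be read. The compounds shown leave open whether 3-methylphenyl in place of 4-methoxyphenyl changes the read-out at all.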